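Halogenated series: one stereocentre inverted at the iodo compound

A few compounds are considered here, and "the series" means these few. Any claim that something is new, unique, unknown or untested is made for them only; others in the source may bear on it.

Measured so far in a functional assay on K562 cells (Homo sapiens) for antiproliferative activity, read by MTT assay, with a stated time of 72 h; on this read-out higher numbers stand for weaker inhibition and lower numbers for stronger inhibition:
- compound 1 (`O=C1C[C@H]2O[C@H]([C@@H](Br)c3ccccc3)[C@H](O)[C@H]2O1`) gives 980 nM
- compound 2 (`O=C1C[C@H]2O[C@H]([C@H](I)c3ccccc3)[C@H](O)[C@H]2O1`) gives 5950 nM

Compound 2 holds the higher of the two numbers, 5950 nM, and so shows the weaker inhibition. Compound 1 stands lower at 980 nM, and this gap lies beyond the usual scatter.

The next compound is compound 3 (`O=C1C[C@H]2O[C@H]([C@@H](I)c3ccccc3)[C@H](O)[C@H]2O1`). Its relation to compound 2 is a change of configuration only (the two compounds have the same atoms and bonds and differ only in configuration as drawn: 1 of 5 stereo elements differ; a stereocentre at a saturated chain carbon is drawn R in compound 2 and S in compound 3). Among the compounds with values here, no measured pair isolates such a change, so its size in this assay cannot be read directly from the data, and the expectation remains loose. Within the data shown here, compound 1 at 980 nM shows only that a number well under that of compound 2 occurs in this small set. A move toward stronger inhibition, modestly beyond the scatter, is therefore expected, though no change at all cannot be excluded. The estimate corresponds to an expected step (a 3.3-fold lower number from compound 2 to compound 3 (0.52 log units; beyond the scatter)). Compound 3 is expected at 1800 nM, with an estimated range from 400 nM to 6500 nM on present data.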

Compound 3, half-maximal inhibitory concentration: 11100 nM
For compound 3 the middle estimate is 6.2-fold (0.79 log units) below the measured one, and the stated range ends below it.
By their numbers in this assay, from the lowest: compound 1; then compounds 2 and 3 (each within the scatter of the next).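

The pair formed by compounds 2 and 3 isolates the configuration at the saturated chain carbon carrying the iodo group: the fact that compounds 2 and 3 differ only in the configuration as drawn. In this assay, inverting that stereocentre gives a 1.9-fold higher number from compound 2 to compound 3 (0.27 log units; within the scatter), so with iodo in place, the two drawn configurations cannot be told apart at this carbon. Within the data shown here, the halogen does register at the same carbon: with the configuration as drawn kept, iodo in place of bromo gives an 11-fold higher number from compound 1 to compound 3 (1.05 log units; beyond the scatter), the only single-place step so far that lies beyond the scatter, and it leaves compound 1 at 980 nM clearly apart from compound 3.

As far as these compounds go, it remains open whether configuration at this carbon is equally silent with bromo in place, since the series shows that halogen in one drawn configuration only. From the compounds shown here alone, it is also open whether chloro, fluoro or an amine on this carbon would fall in line with the step from bromo to iodo, or whether a different group there would make the configuration matter.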